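Trifluoromethylphenyl for dimethoxyphenyl on the saturated ring carbon

This account rests on a few compounds, and the source may have more. Where it says the series, first, only, none or still open, it means among the compounds named here.

Measured so far:
- compound 1 `COc1ccc(OC)c(C2OC(c3cc(OC)c(OC)c(OC)c3)=NN2C(C)=O)c1`: 0.4%
- compound 2 `COc1cccc(/C=N/NC(=O)c2cc(OC)c(OC)c(OC)c2)c1OC`: -0.1%

In a functional assay on BGC-823 cells (Homo sapiens) for antiproliferative activity, read by MTT assay, tested at 1 uM (on this read-out lower numbers stand for a weaker effect and higher numbers for a stronger effect at the one concentration tested), compound 1 gives 0.4%, the higher of the two numbers, but compound 2 at -0.1% sits within the scatter of it, so the two show the same near-absent effect. Among the measured compounds shown here, no step between measured compounds is given, and compound 2 differs from compound 1 in more than one place.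

Compound 3 `COc1cc(C2=NN(C(C)=O)C(c3cccc(C(F)(F)F)c3)O2)cc(OC)c1OC` is the unmeasured compound. Its change from compound 1 is 3-(trifluoromethyl)phenyl in place of 2,5-dimethoxyphenyl on a saturated ring carbon. For the measured compounds named here, nothing among the measured compounds shows what this exchange does on this read-out. With both measured numbers close to zero, the expected step is a number 2.6 percentage points higher from compound 1 to compound 3 (within the scatter), none beyond the scatter in either direction. Compound 3 is therefore estimated to give 3% in this assay, within -10% to 20%.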

Compound 3, a percentage reported as inhibition, at one concentration (the size of the read-out at that concentration, not a potency): 27.9%
Beside the measured number, compound 3's estimate is 24.9 percentage points below it; measured number outside the range, above it.
By their numbers in this assay, from the lowest: compounds 2 and 1 (each within the scatter of the next); then compound 3.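

In this assay the saturated ring carbon is not a silent position: 3-(trifluoromethyl)phenyl in place of 2,5-dimethoxyphenyl gives a number 27.5 percentage points higher from compound 1 to compound 3 (beyond the scatter), so the aryl group here can decide whether the core of compound 1 shows any effect at all. The two groups have the same heavy-atom count and each holds one six-membered aromatic ring, while the entering group has 0 hydrogen-bond acceptors against 2 for the leaving group, and this single step cannot say which difference counts. No measured evidence on the compounds accounts for the step.

Still open, going by these compounds, is whether the gain comes from the trifluoromethyl group itself or from the loss of the two methoxy groups. An unsubstituted phenyl or a chlorophenyl at this carbon would help separate the two, and a single concentration says nothing of potency.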